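The source may hold more compounds than are shown below. What is called first, only, known or untested is meant among the compounds shown, and "the series" means these compounds.

Compound 3, with the structure `Cc1cc(C)c(S(=O)(=O)N2CCC(c3ccccc3)CC2)c(C)c1`, is one of three measured members of a shared core. In an ADME assay on HCT-116 cells (Homo sapiens) for cytotoxicity, read by CellTiter-Glo, with a stated time of 72 h (on this read-out higher numbers stand for weaker inhibition and lower numbers for stronger inhibition), compound 3 gives only a limit of the assay, > 5000 nM. Compound 1, `Cc1cc(C)c(S(=O)(=O)N2CCC(C(=O)N3CCC(C)CC3)CC2)c(C)c1`, also reaches only a limit in this assay, > 5000 nM. Compound 2, `Cc1cc(C)c(S(=O)(=O)N2CCC(N3CCC(C)OC3)CC2)c(C)c1`, likewise gives a limit in this assay, > 5000 nM. The steps among them, a step that the two limits leave unreadable from compound 1 to compound 2, a step that the two limits leave unreadable from compound 1 to compound 3 and a step that the two limits leave unreadable from compound 2 to compound 3, stay unreadable because every value sits at the limit of > 5000 nM in this assay, at which 3 of the 3 values shown sit.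

Compound 4, `Cc1ccc(C2CCN(S(=O)(=O)c3c(C)cc(C)cc3C)CC2)cc1`, differs from compound 3 in one place: methyl in place of hydrogen on an aromatic carbon. Among the compounds with values here, no measured step bears on this particular change, and the steps that are known give no readable size, so nothing in the data argues for a move beyond the scatter in either direction. Compound 4 is therefore expected to remain near the limit, with an estimated value of 8000 nM and a range from 3000 nM to 30000 nM. The step this estimate implies, a step that the limit leaves unreadable from compound 3 to compound 4, is expected to be small.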

Compound 4, half-maximal inhibitory concentration: > 5000 nM
Compound 4 ended at the assay's limit; the forecaster's own chance of this, stated with the estimate: 85%; the middle value does not contradict the limit.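

The steps from compound 1, compound 2 and compound 3 to compound 4 cannot be read in this assay, as all four compounds stop at a limit: the limit of > 5000 nM in this assay, at which 4 of the 4 values shown sit.

The compounds shown leave open how strongly any of them acts and whether methyl in place of hydrogen changes that.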